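A few compounds are considered here, and "the series" means these few. Any claim that something is new, unique, unknown or untested is made for them only; others in the source may bear on it.

Values so far in a physicochemical assay for lipophilicity, read by HPLC, measured as chromatographic lipophilicity, at pH 7.4; on this read-out higher numbers stand for higher lipophilicity and lower numbers for lower lipophilicity
- compound 1 `Cc1ccc(C2CC=NN2C(=O)C(C)(C)C)cc1` gives 6.4
- compound 2 `O=C(C1CCN(c2ccncn2)CC1)N1N=CC[C@H]1c1ccccc1` gives 3.2
- compound 3 `Cc1ccc(C2CC=NN2C(=O)C(C)(C)C)cc1F` gives 6.6

Compound 1 is level with compound 3 within the scatter, and both lie far from compound 2. Compound 4 `CC(C)(C)C(=O)N1N=CCC1c1ccc(S(C)(=O)=O)cc1` differs from compound 1 by methylsulfonyl in place of methyl on an aromatic carbon in one place: methylsulfonyl in place of methyl on an aromatic carbon, para to a large group. For the measured compounds named here, the only measured single-place step a number 0.20 log units higher from compound 1 to compound 3 (within the scatter) is fluoro in place of hydrogen, a different change that says little here. Going by the values given here, no measured step covers this swap, so the size rests on the structural change alone. In this assay a large fall is expected, towards compound 2 at 3.2 but short of it. The expected step is a number 2.00 log units lower from compound 1 to compound 4 (beyond the scatter) and lies beyond the scatter. For compound 4 the estimate is 4.4 with an expected range from 3.7 to 5.1 on this scale.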

Compound 4, distribution coefficient: 4.1
Beside the measured number, compound 4's estimate is 0.30 log units above it; the measured number falls inside the stated range.
By their numbers in this assay, from the lowest: compound 2; then compound 4; then compounds 1 and 3 (each within the scatter of the next).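

In this assay, methylsulfonyl in place of methyl on an aromatic carbon, para to a large group, gives a number 2.30 log units lower from compound 1 to compound 4 (beyond the scatter), whereas the earlier single-place step, a number 0.20 log units higher from compound 1 to compound 3 (within the scatter), stayed within the scatter. A single swap at this position, with the rest of compound 1 unchanged, therefore moves the read-out well beyond the scatter. Nothing available accounts for the size of this step.

From the compounds shown here alone, it remains open whether this size is particular to methylsulfonyl or extends to other groups at this carbon. A methoxy group, an amine or a carboxylic acid in the same place would test this.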